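Lengthening the Hydroxamic Acid Arm: an Untested Step

The compounds below may be only part of what the source reports. "The series", "measured", "known", "first", "only" and "open" are said of these compounds alone.

Compound 1 `COc1ccc(C(=O)c2ccc3c(ccn3Cc3ccc(C(=O)NO)cc3)c2)cc1OC` in an assay on isolated protein for inhibition of histone deacetylase 8 (Homo sapiens) (on this read-out higher numbers stand for weaker inhibition and lower numbers for stronger inhibition), gives 756 nM.
Compound 2 `COc1cc(C(=O)c2ccc3c(ccn3Cc3ccc(C(=O)NO)cc3)c2)cc(OC)c1OC` in this assay gives "not determined" (no result reported).

Within the data shown here, compound 1 is the only one of the pair with a number. Among the measured compounds shown here, for compound 2, which carries one more methoxy group on its benzoyl ring, no result was reported in this assay, so compound 2 stands without a value and no step from compound 1 to compound 2 can be counted.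

Compound 3 `COc1cc(C(=O)c2ccc3c(ccn3Cc3ccc(/C=C/C(=O)NO)cc3)c2)cc(OC)c1OC` differs from compound 2 in one place: 2-(hydroxycarbamoyl)ethenyl in place of hydroxycarbamoyl on an aromatic carbon. The hydroxamic acid is pushed two carbons further from the ring by a double bond.

For the measured compounds named here, since no step between measured compounds exists, nothing measured here tells how such a change plays out in this assay. On this shared core the shorter arm of compound 1 already gives only modest inhibition, and a longer arm is expected to give a somewhat weaker value, beyond the scatter, though a value near compound 1 would not surprise. Compound 3 is estimated at 1500 nM, within 300 nM to 8000 nM.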

Compound 3, half-maximal inhibitory concentration: 2170 nM
Estimate against measurement, compound 3: 1.4-fold (0.16 log units) below; measured number inside the range.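

In this assay, among these compounds, compound 3 gives 2170 nM, but compound 2, its one-place neighbour, carries no number, so no step between compound 2 and compound 3 can be read. Left open is how replacing hydroxycarbamoyl with 2-(hydroxycarbamoyl)ethenyl shifts inhibition on this core. No supporting evidence bears on this value.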